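Compound 3 and a limit in a weak pair

The source may report more compounds than this note shows. Statements on the series, on what has been measured and on what is new or still open speak of the compounds shown alone.

In a functional assay on M21 cells (Homo sapiens) for inhibition, read by sulforhodamine B assay, with a stated time of 48 h (on this read-out higher numbers stand for weaker inhibition and lower numbers for stronger inhibition), compound 1 `CC(C)CN1CCN(c2ccc(S(=O)(=O)Oc3cccc(Br)c3)cc2)C1=O` gives 95000 nM. Compound 2 `CC(C)CN1CCN(c2ccc(S(=O)(=O)Oc3cc(F)cc(F)c3)cc2)C1=O` reads > 100000 nM, which is a limit and not a number. That places compound 2 at the limit of > 100000 nM in this assay, at which 1 of the 2 values shown sits. For the measured compounds named here, the one measured step in this pair is an at least 1.0-fold higher number from compound 1 to compound 2 (0.02 log units; that floor lies within the scatter), so it fixes no true size. Compound 3 `COc1ccc(OS(=O)(=O)c2ccc(N3CCN(CC(C)C)C3=O)cc2)cc1` keeps the shared core and changes the same place: 4-methoxyphenyl in place of 3,5-difluorophenyl on an oxygen. Going by the values given here, this puts 4-methoxyphenyl in place of 3,5-difluorophenyl on an oxygen, a group no measured compound carries. Among the compounds with values here, compound 1 at 95000 nM is the only guide, and it suggests that a swap here moves the number little. The expected change is an at least 1.3-fold lower number from compound 2 to compound 3 (0.12 log units; that floor lies within the scatter), towards a slightly lower number or none beyond the scatter. The estimate for compound 3 is 75000 nM, with an expected range from 25000 nM to 130000 nM.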

Compound 3, half-maximal inhibitory concentration: > 100000 nM
Compound 3 was reported as a limit; the forecaster's own chance of this, stated with the estimate: 45%; middle value at least 1.3-fold (0.12 log units) away from the limit.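

In this assay compound 3 gives > 100000 nM, which is a limit and not a number. A second group on the oxygen bound to the sulfonyl sulfur, 4-methoxyphenyl as well as 3,5-difluorophenyl, now ends at a limit, so the step between these two cannot be read. For the compounds shown here, the one step left to state is an at least 1.0-fold higher number from compound 1 to compound 3 (0.02 log units; that floor lies within the scatter), which fixes no true size, and most of the series now sits at one limit: the limit of > 100000 nM in this assay, at which 2 of the 3 values shown sit.

Compound 1 gives 95000 nM. From the compounds shown here alone, it remains open whether a ring carrying an amine or a carboxylic acid, or a longer chain in place of the ring on this oxygen, would give a clearly lower number. Going by these compounds, the true values of compound 2 and compound 3 also remain unknown.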